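Dropping a Methyl from Compound 3 to Give Compound 4

A few compounds are considered here, and "the series" means these few. Any claim that something is new, unique, unknown or untested is made for them only; others in the source may bear on it.

Of the compounds shown here, three built on the shared core have been measured so far, and none has given a number. Compound 1 `Cc1ccsc1C(c1c(C)noc1C)N1CCN(c2ncnc3c2cnn3-c2ccccc2)CC1` in a functional assay on cells (Rhabdomyosarcoma cell, Homo sapiens) for cytotoxicity (a lower number here means a stronger inhibitor, a higher number a weaker inhibitor), sits at the limit of the assay, > 25000 nM. Compound 2 `c1ccc(C(c2ccco2)N2CCN(c3ncnc4c3cnn4-c3ccccc3)CC2)cc1` likewise gives only the limit, > 25000 nM. Compound 3 `Cc1ccccc1C(c1sccc1C)N1CCN(c2ncnc3c2cnn3-c2ccccc2)CC1`, too, returns only the limit, > 25000 nM. Compound 3 therefore stands at the same limit as the other two, a limit at which all three values sit (the limit of > 25000 nM in this assay, at which 3 of the 3 values shown sit). Within the data shown here, the one single-point step among them, a step that the two limits leave unreadable from compound 1 to compound 3, is a step whose size the two limits leave unreadable.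

The step now followed leads to compound 4 `Cc1ccsc1C(c1ccccc1)N1CCN(c2ncnc3c2cnn3-c2ccccc2)CC1`; the difference is hydrogen in place of methyl on an aromatic carbon, ortho to a large group. Among the measured compounds shown here, no measured step bears readably on this change, since every value in this assay is a limit and the only step among them has no readable size. The expectation is that compound 4 will again fall at or beyond the limit, and the step that the limit leaves unreadable from compound 3 to compound 4 is expected to be none beyond the scatter that can be read. Compound 4 is estimated at 40000 nM, within 10000 nM to 200000 nM.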

Compound 4, half-maximal inhibitory concentration: > 25000 nM
Compound 4: no number, only a limit; the forecaster's own chance of this, stated with the estimate: 85%; the middle value is on the limit's open side.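

Compound 4 gives only a limit, > 25000 nM. The steps to it from compound 1, compound 2 and compound 3 therefore cannot be read, and all four compounds now sit together: the limit of > 25000 nM in this assay, at which 4 of the 4 values shown sit. Left open is how strongly any of the four acts in this assay, and whether 2-methylphenyl and phenyl differ there at all.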